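From methoxy to hydroxy on a chloro compound

The source may hold more compounds than are shown below. What is called first, only, known or untested is meant among the compounds shown, and "the series" means these compounds.

Measured in a functional assay on PC-3 cells (Homo sapiens) for antiproliferative activity, read by MTT assay, with a stated time of 96 h; a lower number here means a stronger inhibitor of growth, a higher number a weaker inhibitor of growth:
- compound 1 `COc1cccc2ccc(Nc3cc(C)ccn3)nc12`: 3820 nM
- compound 2 `COc1cccc2ccc(Nc3cc(Cl)ccn3)nc12`: 11900 nM

Of these two compounds, compound 2 has the higher number and so is the weaker inhibitor of growth. The gap is a 3.1-fold higher number from compound 1 to compound 2 (0.49 log units; beyond the scatter).

The next compound, compound 3 `Oc1cccc2ccc(Nc3cc(Cl)ccn3)nc12`, keeps the chloro group and changes one other place: hydrogen in place of methyl on an oxygen on an aromatic ring. This puts hydrogen in place of methyl on an oxygen on an aromatic ring, turning methoxy into hydroxy.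

For the measured compounds named here, no measured step touches this place, so the evidence is thin. Going by the values given here, the only step available, a 3.1-fold higher number from compound 1 to compound 2 (0.49 log units; beyond the scatter), is a change of a different kind at a different place. Among the compounds with values here, it shows only that one small swap can produce a modest shift, so a step of similar size is a reasonable expectation. The direction is uncertain, but compound 2 sits at the top of the two values, which gives a weak lean towards a lower number.

The expected change is a 2.0-fold lower number from compound 2 to compound 3 (0.30 log units; within the scatter).

For compound 3, the estimated value in this assay is 6000 nM, with an expected range of 1500 nM to 20000 nM.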

Compound 3, concentration for 50% growth inhibition: 2810 nM
Compound 3: middle estimate off by 2.1-fold (0.33 log units), on the high side, within the range that was stated.
By their numbers in this assay, from the lowest: compounds 3 and 1 (each within the scatter of the next); then compound 2.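

In this assay, the oxygen on the aromatic ring proves to be a place where the number responds: taking the methyl off it, so that methoxy becomes hydroxy, gives a 4.2-fold lower number from compound 2 to compound 3 (0.63 log units; beyond the scatter). For the compounds shown here, the earlier step showed only what happens when chloro replaces methyl at a different place, so this is the first look at this position, and it shows that, on the chloro compound, the methyl on this oxygen is not needed for growth inhibition, since the hydroxy compound is the stronger inhibitor of the pair. No measurement of any other property accompanies these values, so the reason for this step remains unknown.

Going by these compounds, whether the same swap would also lower the number on compound 1, which carries methyl where compound 3 carries chloro, stays open, as one step on one compound need not carry over to another. Also open, on these data alone, is how other groups at this place would behave, such as a longer chain like ethoxy in place of methoxy, or an amine in place of hydroxy.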